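This account rests on a few compounds, and the source may have more. Where it says the series, first, only, none or still open, it means among the compounds named here.

In an assay on membranes from HeLa cells for displacement of a labelled ligand from adenosine receptor A3 (Homo sapiens), read by scintillation counting, with a stated time of 180 min, tested at 1 uM (on this read-out higher numbers stand for more inhibition at the one concentration tested (going by the name of the read-out) and lower numbers for less inhibition), three compounds have been measured:
compound 1 `COC(=O)C1=C(C)NC(=S)NC1c1cccs1` gives 1%
compound 2 `CC1=C(C(=O)OC(C)(C)C)C(c2cccs2)NC(=S)N1` gives 22%
compound 3 `CC1=C(C(=O)OCc2ccccc2)C(c2cccs2)NC(=S)N1` gives 24%

Among the measured compounds shown here, compound 3 shows the highest number of the three, but its gap to compound 2 is within the scatter, as a number 2 percentage points higher from compound 2 to compound 3 (within the scatter) shows; only the step of a number 23 percentage points higher from compound 1 to compound 3 (beyond the scatter) lies beyond it. Compound 4 `CC1=C(C(=O)OCc2ccccc2)C(c2ccsc2)NC(=S)N1` differs from compound 3 by thiophen-3-yl in place of thiophen-2-yl on a saturated ring carbon. For the measured compounds named here, none of the measured steps bears on this change: a number 21 percentage points higher from compound 1 to compound 2 (beyond the scatter) and a number 23 percentage points higher from compound 1 to compound 3 (beyond the scatter) both alter the group on the oxygen next to the carbonyl, and a number 2 percentage points higher from compound 2 to compound 3 (within the scatter) stays within the scatter. With nothing pointing either way, the step of no change at the digits printed from compound 3 to compound 4 (within the scatter) in this assay is expected to stay within the scatter. Compound 4 is therefore estimated at 24%, in a range from 8% to 40%.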

Compound 4, a percentage reported as inhibition, at one concentration (the size of the read-out at that concentration, not a potency): 2%
Estimate against measurement, compound 4: 22 percentage points above; measured number below the stated range.
By their numbers in this assay, from the lowest: compounds 1 and 4 (each within the scatter of the next); then compounds 2 and 3 (each within the scatter of the next).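

Swapping thiophen-2-yl for thiophen-3-yl keeps the same atoms and the same counted features, yet the result changes in this assay, with a number 22 percentage points lower from compound 3 to compound 4 (beyond the scatter). Among the compounds shown here, this ring carbon therefore responds to which thiophene carbon carries the bond, something the earlier steps could not show, since they changed only the group on the oxygen next to the carbonyl. No measurement shown here accounts for this step.

On these data alone, it remains open whether thiophen-3-yl would give a similar step with methyl or tert-butyl on that oxygen. As far as these compounds go, how a furan ring or an amine would read at this ring carbon also remains open.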